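The compounds below may be only part of what the source reports. "The series", "measured", "known", "first", "only" and "open" are said of these compounds alone.

Compound 1 `O=C(c1cccnc1)N1CCC(NS(=O)(=O)c2cc(S(=O)(=O)c3ccccc3)ccc2C(F)(F)F)CC1` was tested in an assay on isolated protein for displacement of a labelled ligand from secreted frizzled-related protein 1 (Homo sapiens), read by fluorescence polarization, with a stated time of 30 min (on this read-out lower numbers stand for stronger inhibition and higher numbers for weaker inhibition), and gives 80 nM. Of the two measured compounds this is the higher number; compound 2 `O=S(=O)(NC1CCN(S(=O)(=O)c2cccc(-c3nnn[nH]3)c2)CC1)c1cc(S(=O)(=O)c2ccccc2)ccc1C(F)(F)F` gives 30 nM in this assay, a gap described as beyond the usual scatter. Compound 3 `O=C(O)c1ccc(N2CCC(NS(=O)(=O)c3cc(S(=O)(=O)c4ccccc4)ccc3C(F)(F)F)CC2)cc1` has not yet been measured. It differs from compound 1 in one place: 4-carboxyphenyl in place of (pyridin-3-yl)carbonyl on an amine nitrogen in a ring. Among the measured compounds shown here, no measured pair shows this same change, so the direction of the step is open. The expectation is a step from compound 1 to compound 3 of a 1.3-fold lower number from compound 1 to compound 3 (0.12 log units; within the scatter), a modest shift. Compound 3 is estimated at 60 nM, in a range from 20 nM to 200 nM.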

Compound 3, half-maximal inhibitory concentration: 120 nM
The estimate for compound 3 lay 2.0-fold (0.30 log units) below the measured number, and the stated range covers the measured number.
By their numbers in this assay, from the lowest: compound 2; then compounds 1 and 3 (each within the scatter of the next).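

In this assay, the exchange of (pyridin-3-yl)carbonyl for 4-carboxyphenyl on the amine nitrogen in a ring gives a 1.5-fold higher number from compound 1 to compound 3 (0.18 log units; within the scatter). This step lies within the usual scatter, so the assay does not separate these two groups at this position, even though one brings a carbonyl directly onto the nitrogen and the other an aromatic ring of carbon only. Nothing available explains why the two groups read alike.

Still open, as far as these compounds go, is whether the carboxylic acid matters at all. A plain phenyl group or a methyl ester on the same nitrogen would test this.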